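The source may report more compounds than this note shows. Statements on the series, on what has been measured and on what is new or still open speak of the compounds shown alone.

Working notes on the series. Compound 3 `CCCCCc1cn(C(c2ccccc2)c2cc3cc(Br)ccc3nc2OC)nn1` gives 11.4% in an ADME assay on PC-3 cells (Homo sapiens) for cytotoxicity, read by sulforhodamine B assay, with a stated time of 48 h, tested at 10 uM (a lower number here means less inhibition, a higher number more inhibition at the concentration tested (going by the name of the read-out)), the highest of the three numbers, though its nearest neighbours are within the scatter. Compound 1 `CCCCCCc1cn(C(c2ccccc2)c2cc3cc(Br)ccc3nc2OC)nn1` gives 2.32% and compound 2 `CCCCCCCCc1cn(C(c2ccccc2)c2cc3cc(Br)ccc3nc2OC)nn1` gives 2.27%. The measured steps are all chain-length changes on the same arm: a number 0.1 percentage points lower from compound 1 to compound 2 (within the scatter), a number 9.1 percentage points higher from compound 1 to compound 3 (within the scatter) and a number 9.1 percentage points higher from compound 2 to compound 3 (within the scatter), none beyond the scatter. Compound 4 `COc1nc2ccc(Br)cc2cc1C(c1ccccc1)n1cc(CCO)nn1` differs from compound 3 by hydroxy in place of propyl on a saturated chain carbon, two bonds along the chain from an aromatic carbon. Within the data shown here, no measured step introduces a hydroxy, so this change is not covered by the series; the only available steps, all on this chain, were flat. A step of a number 6.4 percentage points lower from compound 3 to compound 4 (within the scatter) is therefore expected, nothing beyond the scatter. Compound 4 is estimated at 5%, range -6% to 18%.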

Compound 4, a percentage reported as inhibition, at one concentration (the size of the read-out at that concentration, not a potency): 15.5%
For compound 4 the middle estimate is 10.5 percentage points below the measured one; low and high end bracket the measured number.
By their numbers in this assay, from the lowest: compounds 2, 1, 3 and 4 (each within the scatter of the next, the first and the last beyond it).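

The first hydroxy at this place, on a saturated chain carbon two bonds along the chain from an aromatic carbon, stays close to the pentyl chain of compound 3, with a number 4.1 percentage points higher from compound 3 to compound 4 (within the scatter) in this assay. It separates from the longer chains, with a number 13.2 percentage points higher from compound 1 to compound 4 (beyond the scatter) and a number 13.2 percentage points higher from compound 2 to compound 4 (beyond the scatter), the only gaps beyond the scatter in the series. Nothing at hand explains this result.

Compound 4 changes chain length and chain end together, leaving open which of the two matters. An ethyl chain, or an amine or carboxylic acid at this place, would help to separate them.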